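Oxalyl anilide series: aryl ortho substituent on the amide nitrogen

This account rests on a few compounds, and the source may have more. Where it says the series, first, only, none or still open, it means among the compounds named here.

Within the data shown here, compound 2 `C[C@H](NC(=O)C(=O)Nc1ccccc1Cl)C(=O)N[C@@H](CC(=O)O)C(=O)COc1c(F)c(F)cc(F)c1F` is the stronger of the two measured members. In a functional assay on Jurkat cells (Homo sapiens) for inhibition (a lower number here means a stronger inhibitor, a higher number a weaker inhibitor), compound 2 gives 64 nM, the lowest of the two numbers, while compound 1 `C[C@H](NC(=O)C(=O)NCc1ccccc1)C(=O)N[C@@H](CC(=O)O)C(=O)COc1c(F)c(F)cc(F)c1F` gives 300 nM. Among the measured compounds shown here, the only measured step, a 4.7-fold lower number from compound 1 to compound 2 (0.67 log units; beyond the scatter), concerns the group on the amide-type nitrogen. Compound 3 `C[C@H](NC(=O)C(=O)Nc1ccccc1-c1ccc[nH]1)C(=O)N[C@@H](CC(=O)O)C(=O)COc1c(F)c(F)cc(F)c1F` keeps the anilide of compound 2 and changes its substituent: 1H-pyrrol-2-yl in place of chloro on an aromatic carbon. For the measured compounds named here, no measured pair shows a chloro-to-pyrrolyl exchange, and the step from compound 1 to compound 2 swaps the whole group on the nitrogen rather than a substituent on the ring, so it does not directly bear on this change; it shows only that this position of the molecule tolerates alteration with a modest effect. Going by the values given here, with no closer precedent, the expected step of a 1.3-fold higher number from compound 2 to compound 3 (0.10 log units; within the scatter) for compound 3 is not beyond the scatter in either direction. Compound 3 is therefore estimated at 80 nM in this assay, with a range from 25 nM to 300 nM.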

Compound 3, half-maximal inhibitory concentration: 56 nM
The estimate for compound 3 lay 1.4-fold (0.15 log units) above the measured number; the range from low to high includes it.
By their numbers in this assay, from the lowest: compounds 3 and 2 (each within the scatter of the next); then compound 1.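

In this assay, 1H-pyrrol-2-yl in place of chloro gives a 1.1-fold lower number from compound 2 to compound 3 (0.06 log units; within the scatter), so compound 2 and compound 3 stand within the scatter of each other. This place on the aromatic carbon, ortho to a large group, therefore takes a substituent of 5 heavy atoms with one five-membered aromatic ring as well as a single chlorine, with no separation between the two in this assay. The step from the benzyl group also stays clear of the scatter with the larger substituent (a 5.4-fold lower number from compound 1 to compound 3 (0.73 log units; beyond the scatter)), so both ring-substituted anilides shown lie apart from compound 1, and nothing at hand accounts for the two substituents reading alike.

The compounds shown leave open how a 1-methylpyrrol-2-yl or a phenyl group would read at this carbon, and so whether the hydrogen on the pyrrole nitrogen counts for anything here. They also leave open whether an amine, a carboxylic acid or a plain hydrogen at this carbon would stay with compound 2 and compound 3 or fall toward compound 1.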